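The compounds below may be only part of what the source reports. "The series", "measured", "known", "first", "only" and "open" are said of these compounds alone.

Compound 1 `CCC(C(=O)N1CCN(c2cccc(Cl)c2)CC1)N1C(=O)CCC1=O` and compound 2 `CCC(C(=O)N1CCN(c2ccc(C(F)(F)F)cc2)CC1)N1C(=O)CCC1=O` share one core and differ only in the group carried on the aromatic ring and in where that group sits. In a functional assay on the whole organism (strain Swiss) with Mus musculus as the target, in the maximal electroshock model, with a stated time of 0.25 h, at a dose of 300 mg/kg by the intraperitoneal route (on this read-out lower numbers stand for a weaker effect and higher numbers for a stronger effect at the one dose given), compound 1 gives 75%. In this assay compound 2 gives 25%, the lowest of the two numbers, and its gap to compound 1 lies beyond the scatter. Compound 3 `CCC(C(=O)N1CCN(c2ccc(Cl)cc2)CC1)N1C(=O)CCC1=O` is reached from compound 2 by the change (chloro in place of trifluoromethyl on an aromatic carbon). For the measured compounds named here, no measured pair shows this change by itself, so its size can only be expected. Going by the values given here, because compound 1 gives 75% and is the one measured compound that carries chloro, an upward step is expected, a number 35 percentage points higher from compound 2 to compound 3 (beyond the scatter), a step beyond the scatter. Compound 3 is accordingly estimated at 60%, with a range from 30% to 90%.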

Compound 3, a percentage reported as activity, at one dose (the size of the read-out at that dose, not a potency): 0%
Compound 3: middle estimate off by 60 percentage points, on the high side; measured number below the stated range.
By their numbers in this assay, from the lowest: compound 3; then compound 2; then compound 1.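

With chloro held constant, 4-chlorophenyl in place of 3-chlorophenyl gives, in this assay, a number 75 percentage points lower from compound 1 to compound 3 (beyond the scatter), so the place of the chloro on the aromatic ring matters by itself, which compounds 1 and 2 could not show, as they differ in both group and place. Chloro in place of trifluoromethyl, para to a large group, gives a number 25 percentage points lower from compound 2 to compound 3 (beyond the scatter), so at this position chloro does not raise the read-out over trifluoromethyl. The high number of compound 1 therefore belongs to chloro in 3-chlorophenyl, not to chloro wherever it sits on this ring.

The compounds shown leave open how trifluoromethyl reads in the place it holds in 3-chlorophenyl, and how a methoxy group or an amine would read on this ring. Nothing at hand accounts for either step.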